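The source may report more compounds than this note shows. Statements on the series, on what has been measured and on what is new or still open speak of the compounds shown alone.

Measured compounds:
compound 1 `O=C(NCc1ccccc1)c1csc(-c2c[nH]c3ccccc23)n1` — > 100000 nM
compound 2 `O=C(Nc1ccccc1)c1csc(-c2cn(Cc3ccc(Cl)cc3)c3ccccc23)n1` — > 100000 nM

In a functional assay on PC-3 cells (Homo sapiens) for cytotoxicity, read by MTT assay, with a stated time of 48 h, in the presence of a further agent that is not named here (a lower number here means a stronger inhibitor, a higher number a weaker inhibitor), compound 2 returns only a limit, > 100000 nM, and not a number. Compound 1 likewise gives only a limit in this assay, > 100000 nM. So compound 2 stands nowhere on a scale of numbers: both values obtained so far sit at the limit, as the limit of > 100000 nM in this assay, at which 2 of the 2 values shown sit, records, and there is no measured step between them that would show a direction or a size.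

The next compound, compound 3 `O=C(Nc1ccccc1)c1csc(-c2c[nH]c3ccccc23)n1`, differs from compound 2 by hydrogen in place of 4-chlorobenzyl on an aromatic nitrogen. With both known compounds at the limit of this assay, there is no basis for expecting a step beyond the usual scatter in either direction; the expectation is for another limit. The estimated step from compound 2 to compound 3 is a number no higher from compound 2 to compound 3 (the limit leaves the size open), meaning no change. For compound 3 in this assay the estimate is 100000 nM, with an expected range from 30000 nM to 300000 nM.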

Compound 3, half-maximal inhibitory concentration: > 100000 nM
Compound 3 was reported as a limit; the forecaster's own chance of this, stated with the estimate: 85%; the middle value lies on the limit itself.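

Compound 3 also returns only a limit, so the steps linking it to compound 2 and to compound 1 in this assay cannot be read, in size or in direction: the limit of > 100000 nM in this assay, at which 3 of the 3 values shown sit.

The compounds shown leave open whether hydrogen in place of 4-chlorobenzyl, or phenyl in place of benzyl, changes the read-out in this assay at all.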